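The compounds below may be only part of what the source reports. "The series", "measured", "known", "first", "only" and "open" are said of these compounds alone.

For the measured compounds named here, in a functional assay on SiHa cells (Homo sapiens) for inhibition (on this read-out lower numbers stand for stronger inhibition and higher numbers for weaker inhibition), two compounds sharing one core have numbers so far. Compound 1 `COc1cc(/C=C/C(=O)c2cccc(NC(=O)c3c(Cl)cccc3Cl)c2)ccc1O` gives 3.56 ug/mL, and compound 2 `COc1cc(/C=C/C(=O)c2cccc(NC(=O)c3ccco3)c2)ccc1O` gives 0.76 ug/mL, the lower of the two numbers and so the stronger inhibition of the pair. Compound 3 `COc1cc(/C=C/C(=O)c2cccc(NC(=O)C(C)C)c2)ccc1O` has yet to be measured. It keeps the shared core and differs from compound 2 at one place: isopropyl in place of furan-2-yl on a carbonyl carbon. In words, isopropyl stands in place of furan-2-yl on a carbonyl carbon. Going by the values given here, only one measured step bears on this change: a 4.7-fold lower number from compound 1 to compound 2 (0.67 log units; beyond the scatter), where furan-2-yl replaced 2,6-dichlorophenyl on that same carbonyl carbon. It shows that the number in this assay can move with the group at this place, but it was a swap between two ring groups, and no group without a ring has been measured there. The direction is therefore uncertain, though compound 2 already holds the lower number at 0.76 ug/mL. The expected change is a 2.0-fold higher number from compound 2 to compound 3 (0.30 log units; within the scatter), a modest move toward weaker inhibition. For compound 3 the estimated value is 1.5 ug/mL, with an expected range of 0.5 ug/mL to 4.5 ug/mL.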

Compound 3, half-maximal inhibitory concentration: 5.96 ug/mL
The estimate for compound 3 lay 4.0-fold (0.60 log units) below the measured number; measured number above the stated range.
By their numbers in this assay, from the lowest: compound 2; then compounds 1 and 3 (each within the scatter of the next).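

In this assay, for the compounds shown here, isopropyl, the first group without a ring on this carbonyl carbon, takes the number well away from that of furan-2-yl (a 7.8-fold higher number from compound 2 to compound 3 (0.89 log units; beyond the scatter)). The same group stands within the scatter of 2,6-dichlorophenyl (a 1.7-fold higher number from compound 1 to compound 3 (0.22 log units; within the scatter)), so among these three compounds the presence of a ring at this place does not by itself go with the lower number: compound 1 carries a ring and still lies within the scatter of the ringless compound 3, and only compound 2, with furan-2-yl, stands apart. No measurement at hand accounts for this difference between furan-2-yl and the other two groups.

Going by these compounds, what remains open is whether the lower number of compound 2 depends on the oxygen of furan-2-yl or on the five-membered aromatic ring as a whole, which thiophen-2-yl or pyrrol-2-yl at the same carbonyl carbon would help to separate. On these data alone, it is also open how an unsubstituted phenyl or a longer chain such as n-butyl would read in this assay.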